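The source may report more compounds than this note shows. Statements on the series, on what has been measured and on what is new or still open speak of the compounds shown alone.

Compound 1 `COc1nc2ccc(Br)cc2cc1C(c1ccccc1)n1cc(-c2ccccc2F)nn1` carries a 2-fluorophenyl on the triazole of the shared core. In an ADME assay on PC-3 cells (Homo sapiens) for cytotoxicity, read by sulforhodamine B assay, with a stated time of 48 h, tested at 10 uM (on this read-out lower numbers stand for less inhibition and higher numbers for more inhibition at the one concentration tested (going by the name of the read-out)), compound 1 gives 13.4%. Two other compounds share that core. Compound 2 `COc1nc2ccc(Br)cc2cc1C(c1ccccc1)n1cc(-c2ccc(OC(F)(F)F)cc2)nn1` gives 21.6% and compound 3 `COc1nc2ccc(Br)cc2cc1C(c1ccccc1)n1cc(CCCO)nn1` gives 14.7%. Of the three numbers, that of compound 1 is the lowest, yet both steps away from it, a number 8.2 percentage points higher from compound 1 to compound 2 (within the scatter) and a number 1.3 percentage points higher from compound 1 to compound 3 (within the scatter), lie within the scatter, as does a number 6.9 percentage points lower from compound 2 to compound 3 (within the scatter), so the three compounds cannot be told apart on this read-out.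

Compound 4 `COc1nc2ccc(Br)cc2cc1C(c1ccccc1)n1cc(-c2ccccc2C(F)(F)F)nn1` differs from compound 1 by trifluoromethyl in place of fluoro on an aromatic carbon. The step from 2-fluorophenyl to 4-(trifluoromethoxy)phenyl is the closest measured comparison, and it stayed within the scatter, as did the move to 3-hydroxypropyl; neither swap at this position moved the number beyond the noise. Compound 4 is therefore expected to sit at about the same level, and the expected step of a number 2.6 percentage points higher from compound 1 to compound 4 (within the scatter) is no larger than the scatter. The estimate for compound 4 is 16%, within a range from 5% to 30%.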

Compound 4, a percentage reported as inhibition, at one concentration (the size of the read-out at that concentration, not a potency): 17.4%
For compound 4 the middle estimate is 1.4 percentage points below the measured one; low and high end bracket the measured number.
By their numbers in this assay, from the lowest: compounds 1, 3, 4 and 2 (each within the scatter of the next).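

In this assay, trifluoromethyl in place of fluoro on an aromatic carbon, ortho to a large group, gives a number 4 percentage points higher from compound 1 to compound 4 (within the scatter), so a larger group at this same ring carbon does not separate compound 4 from compound 1. The comparisons with the other two groups read the same way, with a number 2.7 percentage points higher from compound 3 to compound 4 (within the scatter) and a number 4.2 percentage points lower from compound 2 to compound 4 (within the scatter), and the four compounds remain indistinguishable on this read-out, whether the group on the triazole is a substituted phenyl or 3-hydroxypropyl. Nothing available offers an explanation for this flat result.

The compounds shown leave open whether any group at this position can move the number beyond the scatter. A carboxylic acid, an amine or a longer chain in place of the 2-(trifluoromethyl)phenyl would test this, as would a trifluoromethyl at another carbon of the phenyl ring.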